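Capping the Phenol: From Compound 3 to Compound 4

The compounds below may be only part of what the source reports. "The series", "measured", "known", "first", "only" and "open" are said of these compounds alone.

This account follows a small series of cyclobutane carboxylic acids that share a sulfur-linked bicyclic core, examined in an assay on HEK293 cells for inhibition of solute carrier family 22 member 12 (Homo sapiens), read by scintillation counting, with a stated time of 12 min; on this read-out lower numbers stand for stronger inhibition and higher numbers for weaker inhibition. The parent, compound 1 `O=C(O)C1(Sc2ccnc3ccncc23)CCC1`, gives 1930 nM in this assay. Compound 2 `Nc1ccc2nccc(SC3(C(=O)O)CCC3)c2c1`, which carries an amino group on the aromatic ring, gives 1790 nM in this assay. Compound 3 `O=C(O)C1(Sc2ccnc3ccc(O)cc23)CCC1` carries a hydroxy group instead; in this assay compound 3 reaches only the limit of > 10000 nM, so a number for it is not known. For the measured compounds named here, the one measured step, an at least 5.5-fold higher number from compound 2 to compound 3 (0.74 log units; beyond the scatter), is the sole point of comparison, and it ends at the limit of > 10000 nM in this assay, at which 1 of the 3 values shown sits, rather than at a number, so the true size of that loss remains open.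

Compound 4 `N#CCOc1ccc2nccc(SC3(C(=O)O)CCC3)c2c1` differs from compound 3 by cyanomethyl in place of hydrogen on an oxygen on an aromatic ring. Going by the values given here, no measured step covers a change of this kind, so the expectation rests only on where compound 3 stands, at the limit, and on compound 1 and compound 2, which sit well inside the measurable range. For compound 4 a move back toward a measurable number is expected, an at least 2.0-fold lower number from compound 3 to compound 4 (0.30 log units; that floor lies within the scatter), with compound 4 estimated at 5000 nM, within a range from 1500 nM to 20000 nM.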

Compound 4, half-maximal inhibitory concentration: 680 nM
The estimate for compound 4 lay 7.4-fold (0.87 log units) above the measured number, outside the stated range (below it).
By their numbers in this assay, from the lowest: compound 4; then compounds 2 and 1 (each within the scatter of the next). At a limit, above all of these: compound 3.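

Placing cyanomethyl on the oxygen on the aromatic ring gives, in this assay, an at least 14-fold lower number from compound 3 to compound 4 (1.16 log units; beyond the scatter), which shows that a free hydroxy group at this position does not close the series off and that capping that oxygen brings the read-out back into the measurable range. The same position also carries more than the amino group did, with a 2.6-fold lower number from compound 2 to compound 4 (0.42 log units; beyond the scatter), so the earlier picture of amino as the better of two substituents there gives way to a third group with a lower number than either. On these data alone, compound 3 itself is a limit and not a number, and the true size of the first step stays open: the limit of > 10000 nM in this assay, at which 1 of the 4 values shown sits.

The compounds shown do not separate the nitrile from the capping of the oxygen as such, and a plain methoxy, a longer chain ending in a nitrile, or a carboxylic acid on the same chain would each speak to that question. As far as these compounds go, whether cyanomethoxy would give a similar number on the core of compound 1 also remains open.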